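Carbamoyl benzazoles: chain-end change against a stability limit

The source may report more compounds than this note shows. Statements on the series, on what has been measured and on what is new or still open speak of the compounds shown alone.

Compound 1, `O=C(NCCCCc1ccccc1)n1nnc2ccccc21`, and compound 2, `O=C(NCCCCc1ccccc1)n1cnc2ccccc21`, carry the same chain on two different cores; the difference between the two cores is not broken down here. Compound 3, `CCCCCCNC(=O)n1cnc2ccccc21`, shares the core of compound 2 and differs from it only at the chain end.

In a physicochemical assay for metabolic stability, read by HPLC, at pH 4.5, tested at 10 uM (a lower number here means that the compound disappears faster, a higher number that the compound lasts longer), compound 1 is reported only as a limit of the assay, > 2 h. Compound 2 is likewise reported only as a limit, > 2 h. Compound 3 is also reported only as a limit, > 2 h. All three measured values thus sit at the limit of > 2 h in this assay, at which 3 of the 3 values shown sit, and no number is read for any of them.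

The change from compound 2 to compound 3 is ethyl in place of phenyl on a saturated chain carbon, four bonds along the chain from an amide-type nitrogen. Its step, a step that the two limits leave unreadable from compound 2 to compound 3, cannot be sized because both of its ends sit at the limit of > 2 h in this assay, at which 3 of the 3 values shown sit.

Compound 4, `CCCCCCNC(=O)n1nnc2ccccc21`, is not yet measured; it joins the core of compound 1 to the chain of compound 3. The change from compound 1 to compound 4 is ethyl in place of phenyl on a saturated chain carbon, four bonds along the chain from an amide-type nitrogen, the same change as that from compound 2 to compound 3, at the same place.

The step from compound 1 to compound 4 is expected to be a step that the limit leaves unreadable from compound 1 to compound 4. That expectation rests on compound 2 and compound 3 both standing at the limit of > 2 h in this assay, at which 3 of the 3 values shown sit, which leaves the change without any readable effect on this assay. In this assay compound 4 is therefore expected to give 3 h, with a range from 1.5 h to 8 h, and most probably to be reported once more only as the limit.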

Compound 4, half-life: > 2 h
Compound 4: no number, only a limit; the forecaster's own chance of this, stated with the estimate: 85%; the middle value is on the limit's open side.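

No new step can be read in this assay, since compound 1 and compound 4 are each reported only as a limit and the step between them has no readable size: the limit of > 2 h in this assay, at which 4 of the 4 values shown sit.

The compounds shown leave open the actual half-life of all four compounds, and so whether ethyl in place of phenyl has any effect on either core.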